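The source may report more compounds than this note shows. Statements on the series, on what has been measured and on what is new or still open speak of the compounds shown alone.

In an ADME assay on MT4 cells (Homo sapiens) for cytotoxicity, read by MTT assay (on this read-out higher numbers stand for lower toxicity in this test and lower numbers for higher toxicity in this test), three compounds with a shared core have been measured. Compound 1 `Cc1cccc(C(=O)N(C(=S)OCCN2C(=O)c3ccccc3C2=O)c2ccc(Cl)cc2)c1` gives 58000 nM, and compound 3 `O=C1c2ccccc2C(=O)N1CCOC(=S)N(C(=O)c1ccc([N+](=O)[O-])cc1Cl)c1ccc(Cl)cc1` gives 19000 nM. Compound 2 `Cc1ccc(N(C(=O)c2cccc(C)c2)C(=S)OCCN2C(=O)c3ccccc3C2=O)cc1` stands at > 100000 nM, which is a limit of the assay and not a number. Its position on the scale is therefore given only by the limit of > 100000 nM in this assay, at which 1 of the 3 values shown sits. Methyl in place of chloro on an aromatic carbon gives an at least 1.7-fold higher number from compound 1 to compound 2 (0.23 log units; that floor lies within the scatter).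

Compound 4 `Cc1ccc(N(C(=O)c2ccc(F)cc2F)C(=S)OCCN2C(=O)c3ccccc3C2=O)cc1` has not yet been measured. Its difference from compound 2 is 2,4-difluorophenyl in place of 3-methylphenyl on a carbonyl carbon. The nearest measured precedent is the change that leads to compound 3, which also removes 3-methylphenyl from that carbonyl carbon. There, 2-chloro-4-nitrophenyl entered and the result was a 3.1-fold lower number from compound 1 to compound 3 (0.48 log units; beyond the scatter). That step is modest, its entering group is a different one, and it starts from compound 1 rather than compound 2, so it offers only partial guidance. A downward step of similar or smaller size is therefore expected in this assay, and a reading at the limit remains possible. The expected change is an at least 1.6-fold lower number from compound 2 to compound 4 (0.22 log units; that floor lies within the scatter). For compound 4, the estimated value is 60000 nM, with an expected range from 22000 nM to 100000 nM.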

Compound 4, half-maximal cytotoxic concentration: 20000 nM
The estimate for compound 4 lay 3.0-fold (0.48 log units) above the measured number; the measured number lies below the stated range.
By their numbers in this assay, from the lowest: compounds 3 and 4 (each within the scatter of the next); then compound 1. At a limit, above all of these: compound 2.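

Replacing 3-methylphenyl with 2,4-difluorophenyl on this carbonyl carbon gives an at least 5.0-fold lower number from compound 2 to compound 4 (0.69 log units; beyond the scatter) in this assay, so a clear fall in the number at this position is now seen from compound 2 as well, and with an entering group other than 2-chloro-4-nitrophenyl. Among these compounds, until now the only readable change at this carbonyl carbon was a 3.1-fold lower number from compound 1 to compound 3 (0.48 log units; beyond the scatter) and it started from a different compound; the two changes now point the same way, and each removes 3-methylphenyl, though they share neither starting compound nor entering group. The new step gives only a floor for its size, since compound 2 stands at a limit and not at a number: the limit of > 100000 nM in this assay, at which 1 of the 4 values shown sits.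

The compounds shown leave open whether a plain phenyl, a single fluorine on that phenyl or a saturated cyclohexyl group on this carbonyl carbon would lower the number in the same way, so the part played by the fluorines themselves stays unresolved. They also leave open whether 2,4-difluorophenyl would have a like effect on compound 1, which carries chloro in place of methyl.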